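The source may report more compounds than this note shows. Statements on the series, on what has been measured and on what is new or still open speak of the compounds shown alone.

In a functional assay on HCT-116 cells (Homo sapiens) for inhibition, read by MTT assay, with a stated time of 2 days (a lower number here means a stronger inhibitor of growth, a higher number a weaker inhibitor of growth), compound 1 `Nc1ccccc1NC(=O)c1ccc(NCC(=O)Nc2ccc([N+](=O)[O-])cc2)cc1` gives 6500 nM as a measured number. Compound 2 `Cc1ccc(NC(=O)CNc2ccc(C(=O)Nc3ccccc3N)cc2)cc1` gives > 100000 nM as a limit of the assay, not a number. Going by the values given here, compound 3 `COc1ccc(NC(=O)CNc2ccc(C(=O)Nc3ccccc3N)cc2)cc1` has methoxy in place of methyl on an aromatic carbon, para to a large group methoxy in place of methyl on an aromatic carbon as its only difference from compound 2. Among the compounds with values here, the one measured step of an at least 15-fold higher number from compound 1 to compound 2 (1.18 log units; beyond the scatter) is large, but it swaps nitro for methyl and does not involve methoxy, so no step beyond the scatter is expected in this assay here. The estimated step of an at least 1.4-fold lower number from compound 2 to compound 3 (0.15 log units; that floor lies within the scatter) therefore stays small. Compound 3 is estimated at 70000 nM within an expected range of 15000 nM to 100000 nM as the likely outcome.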

Compound 3, concentration for total growth inhibition: 38000 nM
Compound 3: middle estimate off by 1.8-fold (0.27 log units), on the high side; measured number inside the range.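

In this assay, methoxy in place of methyl, para to a large group, gives an at least 2.6-fold lower number from compound 2 to compound 3 (0.42 log units; beyond the scatter) and so changes the result beyond the scatter. Nitro still gives the lowest number of the three, with a 5.8-fold higher number from compound 1 to compound 3 (0.77 log units; beyond the scatter), which places compound 3 between compound 1 and compound 2. The step from methyl to methoxy is only a floor, as compound 2 stands at a limit of the assay, not a number: the limit of > 100000 nM in this assay, at which 1 of the 3 values shown sits.

Where an amine, a hydroxyl or a carboxylic acid would fall in this order stays open. So does the true size of the step from compound 2.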